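Carbamate Ring Swap in an HDAC6 Sulfamide Series

The source may hold more compounds than are shown below. What is called first, only, known or untested is meant among the compounds shown, and "the series" means these compounds.

In an assay for inhibition of protein deacetylase HDAC6 (Homo sapiens) (on this read-out higher numbers stand for weaker inhibition and lower numbers for stronger inhibition), compound 1 `N[C@@H](CCCCNS(N)(=O)=O)C(=O)Nc1nc(-c2ccccc2)cs1` gives 1100 nM; compound 2 `NS(=O)(=O)NCCCC[C@H](NC(=O)OCc1ccc(Cl)cc1)C(=O)Nc1nc(-c2ccccc2)cs1` gives 530 nM; compound 3 `NS(=O)(=O)NCCCC[C@H](NC(=O)OCc1cccc(Cl)c1)C(=O)Nc1nc(-c2ccccc2)cs1` gives 280 nM.

Compound 3 carries the lowest number of the three, but its gap to compound 2, a 1.9-fold lower number from compound 2 to compound 3 (0.28 log units; within the scatter), lies within the scatter, so the two are not ordered; the other gap is a 3.9-fold lower number from compound 1 to compound 3 (0.59 log units; beyond the scatter). Compound 4 `NS(=O)(=O)NCCCC[C@H](NC(=O)OCc1cccnc1)C(=O)Nc1nc(-c2ccccc2)cs1` differs from compound 3 by pyridin-3-yl in place of 3-chlorophenyl on a saturated chain carbon bound to an oxygen next to a carbonyl group. Going by the values given here, no measured step makes this kind of exchange. Among the compounds with values here, the only step at this place, a 1.9-fold lower number from compound 2 to compound 3 (0.28 log units; within the scatter), stayed within the scatter, while a 2.1-fold lower number from compound 1 to compound 2 (0.32 log units; beyond the scatter) and a 3.9-fold lower number from compound 1 to compound 3 (0.59 log units; beyond the scatter) show a modest gain from the carbamate itself. Compound 4 is therefore expected to show a small step, a 1.8-fold higher number from compound 3 to compound 4 (0.25 log units; within the scatter), estimated at 500 nM with a range of 200 nM to 1300 nM.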

Compound 4, half-maximal inhibitory concentration: 600 nM
Compound 4: the middle estimate sits 1.2-fold (0.08 log units) below what was measured; the measured number falls inside the stated range.
By their numbers in this assay, from the lowest: compounds 3, 2, 4 and 1 (each within the scatter of the next, the first and the last beyond it).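

Pyridin-3-yl in place of 3-chlorophenyl brings the first exchange of the ring at this place to go beyond the scatter (a 2.1-fold higher number from compound 3 to compound 4 (0.33 log units; beyond the scatter)), so the group at this place can matter. Against 4-chlorophenyl the same ring leaves compound 2 and compound 4 unordered (a 1.1-fold higher number from compound 2 to compound 4 (0.05 log units; within the scatter)). Unlike the two chlorinated carbamates, the ((pyridin-3-yl)methoxy)carbonyl group stays within the scatter of hydrogen (a 1.8-fold lower number from compound 1 to compound 4 (0.26 log units; within the scatter)).

Nothing available explains these differences. From the compounds shown here alone, what an unsubstituted phenyl or a pyridin-4-yl group would give at this place remains open.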